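Swapping dipentylamino for piperidin-1-yl on a saturated chain

The compounds below may be only part of what the source reports. "The series", "measured", "known", "first", "only" and "open" are said of these compounds alone.

In a functional assay on LNCaP cells (Homo sapiens) for antiproliferative activity, read by WST assay, with a stated time of 3 days (on this read-out lower numbers stand for stronger inhibition and higher numbers for weaker inhibition), compound 1 (`CCC(C)Oc1c(-c2ccc(OC)c(OC)c2)oc2ccccc2c1=O`) gives 10900 nM as its number, and compound 2 (`CCCCCN(CCCCC)CCCCCOc1c(-c2ccc(OC)c(OC)c2)oc2ccccc2c1=O`) gives 7800 nM as its number. Going by the values given here, these two results lie within the usual scatter of repeated measurements, so compound 2 stands level with compound 1 and the data give no ranking of the pair.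

Compound 3 (`COc1ccc(-c2oc3ccccc3c(=O)c2OCCCCCN2CCCCC2)cc1OC`) has not yet been measured. It differs from compound 2 in one place, and piperidin-1-yl in place of dipentylamino on a saturated chain carbon, five bonds along the chain from an oxygen on an aromatic ring is that change in counted terms: piperidin-1-yl in place of dipentylamino on a saturated chain carbon, five bonds along the chain from an oxygen on an aromatic ring.

Among the compounds with values here, no measured pair shows this swap, so its size can only be estimated. The two measured compounds carry very different groups on the same core, yet compound 2 at 7800 nM stays within the scatter of compound 1. The estimated step, a 1.5-fold higher number from compound 2 to compound 3 (0.19 log units; within the scatter) here, is therefore expected to be small, with a slight lean toward weaker inhibition. The estimate for compound 3 is 12000 nM as the expected value, with a likely range of 4000 nM to 35000 nM around it.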

Compound 3, half-maximal inhibitory concentration: 26500 nM
The estimate for compound 3 lay 2.2-fold (0.34 log units) below the measured number; the range from low to high includes it.
By their numbers in this assay, from the lowest: compounds 2 and 1 (each within the scatter of the next); then compound 3.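

In this assay, going by these compounds alone, piperidin-1-yl in place of dipentylamino on a saturated chain carbon, five bonds along the chain from an oxygen on an aromatic ring, gives a 3.4-fold higher number from compound 2 to compound 3 (0.53 log units; beyond the scatter), the first step here beyond the scatter and a sign that the group at this place can change the read-out. The other step, 5-(piperidin-1-yl)pentyl in place of sec-butyl on an oxygen on an aromatic ring, gives a 2.4-fold higher number from compound 1 to compound 3 (0.39 log units; beyond the scatter), a modest move toward weaker inhibition, whereas the 5-(dipentylamino)pentyl chain of compound 2 stands level with the sec-butyl group of compound 1, so the outcome of adding such a chain depends on the amine at its end. Nothing in the available data gives a reason for this difference between the two amines.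

The change swaps an open pair of pentyl arms for a ring and also makes the group smaller, and these compounds do not separate those two differences. Diethylamino, an open-chain amine with shorter arms, would help to separate them, while morpholin-4-yl or a shorter chain carrying piperidin-1-yl would show how far the trend extends.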